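The compounds below may be only part of what the source reports. "The series", "measured", "known", "first", "only" and "open" are said of these compounds alone.

Working notes on the series. Three compounds sharing a core carry measurements in a functional assay on A549 cells (Homo sapiens) for antiproliferative activity, read by MTT assay, with a stated time of 48 h; on this read-out lower numbers stand for stronger inhibition and higher numbers for weaker inhibition: compound 1 `O=C(/C=C\Nc1ccc(F)cc1)c1cn(-c2ccccc2)nc1-c1ccc(F)cc1` gives 5780 nM, compound 2 `COc1ccc(-c2nn(-c3ccccc3)cc2C(=O)/C=C\Nc2cc(OC)c(OC)c(OC)c2)cc1` gives 11200 nM, and compound 3 `COc1cc(-c2nn(-c3ccccc3)cc2C(=O)/C=C\Nc2ccc(F)cc2)cc(OC)c1OC` gives 15600 nM. Against the two other numbers, compound 3 sits with compound 2 inside the usual scatter, while compound 1 lies beyond it with the lower number of the pair. Compound 4 `COc1cc(-c2nn(-c3ccccc3)cc2C(=O)/C=C\Nc2ccc(Cl)cc2)cc(OC)c1OC` has not been measured in this assay. It differs from compound 3 in a single place: chloro in place of fluoro on an aromatic carbon. Among the compounds with values here, no measured pair in the set shows the effect of this exchange, so the expected size of the step rests only on its small extent, and no shift beyond the scatter in this assay is expected in either direction. The step from compound 3 to compound 4 is therefore estimated at a 1.3-fold lower number from compound 3 to compound 4 (0.11 log units; within the scatter). For compound 4 the expected value in this assay is 12000 nM, within a range from 5000 nM to 30000 nM.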

Compound 4, half-maximal inhibitory concentration: 8670 nM
Compound 4: middle estimate off by 1.4-fold (0.14 log units), on the high side, within the range that was stated.
By their numbers in this assay, from the lowest: compounds 1, 4, 2 and 3 (each within the scatter of the next, the first and the last beyond it).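

In this assay, within the data shown here, the exchange of the 4-fluorophenyl for the 4-chlorophenyl gives the first single-place comparison, a 1.8-fold lower number from compound 3 to compound 4 (0.26 log units; within the scatter). On this one pair, the halogen on this aromatic carbon, para to a large group, can be changed from fluoro to chloro without a shift beyond the scatter, though the pair alone sets no trend for the position. No measurement in hand bears on the reason for this step.

As far as these compounds go, what bromo, a nitrile or an amine on the same carbon would give remains open, as does the result of removing the halogen altogether. Also open, from the compounds shown here alone, is whether the same exchange made in compound 1, which carries the same 4-fluorophenylamino group on a different aryl substitution, would give a step of similar size.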